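A few compounds are considered here, and "the series" means these few. Any claim that something is new, unique, unknown or untested is made for them only; others in the source may bear on it.

Measured so far:
- compound 1 `CC[C@@H]1O[C@@]1(C)[C@@H]1OC(=O)[C@H](C)[C@@H](O[C@H]2C[C@@](C)(OC)[C@@H](O)[C@H](C)O2)[C@H](C)[C@@H](O[C@@H]2O[C@H](C)C[C@H](N(C)C)[C@H]2O)[C@@]2(C)C[C@@H](C)[C@H](O2)[C@@H]1C`: 10.2 uM
- compound 2 `CO[C@]1(C)C[C@H](O[C@H]2[C@H](C)[C@@H](O[C@@H]3O[C@H](C)C[C@H](N(C)C)[C@H]3O)[C@@]3(C)C[C@@H](C)[C@H](O3)[C@H](C)[C@H](C(C)=O)OC(=O)[C@@H]2C)O[C@@H](C)[C@@H]1O`: 12.3 uM

For the measured compounds named here, in a functional assay on THP-1 cells (Homo sapiens), read by MTT assay, with a stated time of 4 days (on this read-out lower numbers stand for an effect already at smaller amounts and higher numbers for an effect only at larger amounts of compound), compound 2 gives 12.3 uM, and this number cannot be told apart from the one for compound 1, which gives 10.2 uM.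

Compound 3 `CO[C@]1(C)C[C@H](O[C@H]2[C@H](C)[C@@H](O[C@@H]3O[C@H](C)C[C@H](N(C)C)[C@H]3O)[C@@]3(C)C[C@@H](C)[C@H](O3)[C@H](C)[C@H](/C(C)=N/O)OC(=O)[C@@H]2C)O[C@@H](C)[C@@H]1O` keeps the core of compound 2 but loses the acetyl, on a saturated ring carbon next to the ring oxygen: a group of 4 heavy atoms (2 carbon, 1 nitrogen, 1 oxygen; no ring) in place of a group of 3 heavy atoms (2 carbon, 1 oxygen; no ring), on a saturated ring carbon.

Going by the values given here, only one measured step bears on this change. It also exchanges a group on a saturated ring carbon, and it came out small: a 1.2-fold higher number from compound 1 to compound 2 (0.08 log units; within the scatter). Among the compounds with values here, one step is thin evidence, and no measured compound yet carries the entering group. Even so, a large shift in this assay is not expected.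

The expected step is a 1.0-fold lower number from compound 2 to compound 3 (0.01 log units; within the scatter), which would be none beyond the scatter. The estimate for compound 3 is 12 uM, with an expected range from 6 uM to 25 uM.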

Compound 3, concentration for half-maximal effect: 12.3 uM
Beside the measured number, compound 3's estimate is 1.0-fold (0.01 log units) below it; the range from low to high includes it.
By their numbers in this assay, from the lowest: compounds 1, 2 and 3 (each within the scatter of the next).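

In this assay, putting the nitrogen-bearing group of compound 3 in place of the acetyl gives no change at the digits printed from compound 2 to compound 3 (within the scatter), so adding a hydrogen-bond donor on this saturated ring carbon next to the ring oxygen leaves the number within the scatter. The comparison with the larger group carrying a three-membered ring gives a 1.2-fold higher number from compound 1 to compound 3 (0.08 log units; within the scatter), so all three groups seen at this position are alike in this read-out, despite their different sizes and atoms. Nothing measured here accounts for this sameness.

The compounds shown leave open whether an amine or a carboxylic acid on this ring carbon would shift the number beyond the scatter. On these data alone, whether a longer chain in the same place would do so also remains open.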